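Replacing a ring substituent at the aromatic core of a TRPV1 antagonist

This account rests on a few compounds, and the source may have more. Where it says the series, first, only, none or still open, it means among the compounds named here.

Of the compounds shown here, two sharing one core have been measured in a functional assay on CHO-K1 cells for antagonist activity at transient receptor potential cation channel subfamily V member 1 (Homo sapiens), read by FLIPR; on this read-out higher numbers stand for weaker inhibition and lower numbers for stronger inhibition. Compound 1, `CC(C(=O)NCc1ccc(C(F)(F)F)nc1NCC1CCN(C(=O)OC(C)(C)C)CC1)c1ccc(NS(C)(=O)=O)c(F)c1`, gives 19.3 nM in this assay. Within the data shown here, compound 2, `CC(C(=O)NCc1ccc(C(F)(F)F)nc1N1CCCCC1C)c1ccc(NS(C)(=O)=O)c(F)c1`, gives 2.9 nM in this assay, the lowest of the two numbers, with compound 1 as its only neighbour; the gap between these two values lies beyond the scatter of repeated measurements. Among the measured compounds shown here, no step between two measured compounds that differ in a single place is available, so the effect of a single change is not yet known.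

Compound 3, `CC(C(=O)NCc1ccc(C(F)(F)F)nc1N1CCC(CN(C)C)CC1)c1ccc(NS(C)(=O)=O)c(F)c1`, has not been measured. It differs from compound 2 in one place: 4-((dimethylamino)methyl)piperidin-1-yl in place of 2-methylpiperidin-1-yl on an aromatic carbon. The group that enters is larger than the one that leaves and carries an additional hydrogen-bond acceptor. For the measured compounds named here, with only two measured compounds to lean on, the expected size of the step from compound 2 to compound 3 is modest and towards a higher number, estimated as a 3.1-fold higher number from compound 2 to compound 3 (0.49 log units; beyond the scatter). For compound 3 the estimate in this assay is 9 nM, within a range of 3 nM to 35 nM.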

Compound 3, inhibition constant: 2.1 nM
Compound 3: the middle estimate sits 4.3-fold (0.63 log units) above what was measured, and the stated range ends above it.
By their numbers in this assay, from the lowest: compounds 3 and 2 (each within the scatter of the next); then compound 1.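

In this assay, putting 4-((dimethylamino)methyl)piperidin-1-yl in place of 2-methylpiperidin-1-yl gives a 1.4-fold lower number from compound 2 to compound 3 (0.14 log units; within the scatter) and this step lies within the scatter, so compound 2 and compound 3 cannot be told apart on this read-out. Among these compounds, this is the first direct view of a single change at this position, an aromatic carbon next to the ring nitrogen, and it shows that the read-out holds when the entering group has more heavy atoms, a second nitrogen and an additional hydrogen-bond acceptor. Nothing available here explains why the two groups read alike.

From the compounds shown here alone, the swap removes the 2-methyl group and adds the 4-((dimethylamino)methyl) side chain in one step, so the share of each remains open, and a plain piperidin-1-yl group at this position would be the compound to separate them. Going by these compounds, it also remains open whether the side chain's amine matters at all, a question that a carboxylic acid at the end of the same side chain, or a simple 4-methylpiperidin-1-yl group, would put to the test.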